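Ethoxy to acetoxy: working notes on compound 3

A few compounds are considered here, and "the series" means these few. Any claim that something is new, unique, unknown or untested is made for them only; others in the source may bear on it.

Of the compounds shown here, two sharing one core have been measured so far: compound 1 (`COCC(=O)OCCc1c(-c2ccccc2Cl)c2cc(Cl)ccc2[nH]c1=O`) and compound 2 (`CCOCC(=O)OCCc1c(-c2ccccc2Cl)c2cc(Cl)ccc2[nH]c1=O`). In an ADME assay on HepG2 2.2.15 cells (Homo sapiens) for cytotoxicity (a lower number here means that less compound is tolerated, a higher number that more compound is tolerated), compound 1 gives 74000 nM and compound 2 gives 130000 nM on the same read-out. These two values lie within the scatter of each other, so compound 2 cannot be separated from compound 1. The next compound is compound 3 (`CC(=O)OCC(=O)OCCc1c(-c2ccccc2Cl)c2cc(Cl)ccc2[nH]c1=O`), with acetyl in place of ethyl on an oxygen on a saturated carbon, and acetyl in place of ethyl on an oxygen on a saturated carbon is the counted difference. Among the measured compounds shown here, only one measured step bears on this: a 1.8-fold higher number from compound 1 to compound 2 (0.24 log units; within the scatter) with methyl in place of hydrogen on a saturated chain carbon bound to an oxygen on a saturated carbon. For the measured compounds named here, that step stays within the scatter, but it is a single pair, and no measured compound carries acetyl on that oxygen. No step beyond the scatter is therefore expected in this assay in either direction. The estimated change is a 1.3-fold lower number from compound 2 to compound 3 (0.11 log units; within the scatter) and no more than that. For compound 3 the expected value is 100000 nM with 45000 nM to 200000 nM as the estimated range.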

Compound 3, half-maximal cytotoxic concentration: 100000 nM
Compound 3: the middle estimate sits on the measured number at the digits printed; low and high end bracket the measured number.
By their numbers in this assay, from the lowest: compounds 1, 3 and 2 (each within the scatter of the next).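

In this assay, the step from an ether to an ester end group on this oxygen gives a 1.3-fold lower number from compound 2 to compound 3 (0.11 log units; within the scatter) and, measured against the smaller methyl group, a 1.4-fold higher number from compound 1 to compound 3 (0.13 log units; within the scatter) as well, so acetyl cannot be separated from either ethyl or methyl at this place. Compound 2 and compound 1 had only shown two simple alkyl groups on this oxygen to be indistinguishable; acetyl differs from them in kind, entering with 1 hydrogen-bond acceptor and 1 double bond outside aromatic rings, and the read-out still stays within the scatter across all three compounds. No supporting measurement accompanies these numbers to say anything about what lies behind them.

Still open, from the compounds shown here alone, is whether a group of a different type on this oxygen, such as an amine, a carboxylic acid or a longer chain, would move the number beyond the scatter in either direction. All three compounds keep the shared core and the rest of the side chain unchanged, so these values say nothing about how the read-out responds to changes elsewhere in the structure.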